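The source may hold more compounds than are shown below. What is called first, only, known or untested is meant among the compounds shown, and "the series" means these compounds.

Measured so far:
compound 1 `O=C(NC(=S)N1CCc2c(OCc3ccccc3)cccc21)c1ccccc1`: > 50000 nM
compound 2 `O=C(NC(=S)N1CCc2c(OCCCCCOc3ccc(Cl)cc3)cccc21)c1ccc(F)cc1`: 31100 nM

In an ADME assay on Huh-7 cells (Homo sapiens) for cytotoxicity (a higher number here means that more compound is tolerated, a lower number that less compound is tolerated), compound 1 reaches only a limit of the assay, > 50000 nM, which is the limit of > 50000 nM in this assay, at which 1 of the 2 values shown sits. Within the data shown here, compound 2 gives 31100 nM in this assay and so holds the only real number of the two. Compound 3 `O=C(NC(=S)N1CCc2c(OCCCCCOc3ccc(Cl)cc3)cccc21)c1ccco1` differs from compound 2 by furan-2-yl in place of 4-fluorophenyl on a carbonyl carbon. Among the measured compounds shown here, no measured step of this kind is available, so the expected step of a 1.1-fold higher number from compound 2 to compound 3 (0.05 log units; within the scatter) in this assay is small, within the usual scatter, with no firm direction. Compound 3 is therefore expected at about 35000 nM, estimated between 15000 nM and 70000 nM.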

Compound 3, half-maximal cytotoxic concentration: 4620 nM
The estimate for compound 3 lay 7.6-fold (0.88 log units) above the measured number; the measured number lies below the stated range.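

In this assay, the group on the carbonyl carbon turns out to matter: furan-2-yl in place of 4-fluorophenyl gives a 6.7-fold lower number from compound 2 to compound 3 (0.83 log units; beyond the scatter), so less compound is tolerated. This single step lies beyond the usual scatter, so exchanging one aromatic ring for another is not a neutral change at this position. Nothing measured here accounts for the drop.

Going by these compounds, whether it is specific to furan-2-yl remains open, since a thiophene ring, a pyridine ring or a small methyl group on the same carbonyl carbon might behave differently. On these data alone, whether the step holds with a shorter chain elsewhere in the molecule also remains open.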